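The compounds below may be only part of what the source reports. "The series", "measured", "known", "first", "only" and "open" are said of these compounds alone.

Measured compounds:
- compound 1, `CC(CC(=O)O)N1Cc2ccc(NC(=O)CC3CCNCC3)cc2C1=O`: 2700 nM
- compound 2, `O=C(O)CN1Cc2ccc(NC(=O)CCCC3CCNCC3)cc2C1=O`: 66000 nM

Compound 1 holds the lower of the two numbers in a functional assay on a cell-free system (Platelet, plasma, Homo sapiens) for inhibition (on this read-out higher numbers stand for weaker inhibition and lower numbers for stronger inhibition), with compound 2 standing at the higher number; the gap between the two lies beyond the scatter. For the measured compounds named here, compound 2 differs from compound 1 in more than one place, so no single-change step is drawn between them; their two values show only the gap itself.

Compound 3, `O=C(O)CCN1Cc2ccc(NC(=O)CC3CCNCC3)cc2C1=O`, is the compound still to be measured in this assay. Relative to compound 1 the change is hydrogen in place of methyl on a saturated chain carbon bound to an amide-type nitrogen in a ring and a saturated chain carbon, a change on a saturated chain carbon bound to an amide-type nitrogen in a ring and a saturated chain carbon. Going by the values given here, no measured pair isolates this change, so the expected step is a modest weakening of inhibition, a 1.9-fold higher number from compound 1 to compound 3 (0.27 log units; within the scatter), with a fair chance that it falls within the scatter. Compound 3 is estimated at 5000 nM, within a range of 1500 nM to 20000 nM.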

Compound 3, half-maximal inhibitory concentration: 7400 nM
Compound 3: middle estimate off by 1.5-fold (0.17 log units), on the low side; low and high end bracket the measured number.
By their numbers in this assay, from the lowest: compound 1; then compound 3; then compound 2.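

In this assay, going from the 1-(carboxymethyl)ethyl group to the 2-carboxyethyl group gives a 2.7-fold higher number from compound 1 to compound 3 (0.44 log units; beyond the scatter), a modest step but one beyond the scatter. This is the only single-change pair shown, and it establishes that the methyl on this saturated chain carbon counts: the number rises when hydrogen stands in its place. No evidence on the cause of this step is at hand.

As far as these compounds go, it remains open whether ethyl or phenyl on this same carbon would lower the number further than methyl does. Also open, from the compounds shown here alone, is how carboxymethyl would fare with the rest of compound 1 unchanged, since compound 2 carries that group but differs from compound 1 in more than one place.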